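The compounds below may be only part of what the source reports. "The series", "measured", "known", "first", "only" and "open" are said of these compounds alone.

Compound 1 `Brc1ccc(NCc2nc3ccc(Br)cc3[nH]2)cc1` — 23.5%
Compound 2 `Cc1ccc(NCc2nc3ccc(Br)cc3[nH]2)cc1` — 23.5%
Compound 3 `Clc1cccc(NCc2nc3ccccc3[nH]2)c1` — 41.1%

Three compounds have been run in a functional assay on the whole organism (strain albino) for inhibition, with Rattus norvegicus as the target, read by paw edema, with a stated time of 120 min, at a dose of 100 mg/kg by the oral route; on this read-out lower numbers stand for less inhibition and higher numbers for more inhibition at the one dose given (going by the name of the read-out). Compound 1 gives 23.5%, and compound 2 gives 23.5%, so the two stand level, together the lowest pair among the three numbers; the step of no change at the digits printed from compound 1 to compound 2 (within the scatter) is a methyl in place of bromo on an aromatic carbon. Among the measured compounds shown here, compound 3 gives 41.1%, a number well above compound 1 and beyond the scatter, though compound 3 differs from compound 1 in more than one place, so no single step is drawn between them.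

Compound 4 `Brc1ccc(NCc2nc3ccccc3[nH]2)cc1` is not yet measured. It differs from compound 1 by hydrogen in place of bromo on an aromatic carbon, the change sitting on the shared core rather than on the aniline ring. For the measured compounds named here, no measured step removes a bromo from the core, so only the indirect hint from compound 3 bears on it. Compound 4 is therefore expected to sit near compound 1, with the step of a number 6.5 percentage points higher from compound 1 to compound 4 (within the scatter) estimated to be small, and an estimated value of 30%, within a range from 15% to 45%.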

Compound 4, a percentage reported as inhibition, in the whole organism at one dose (the size of the read-out at that dose, not a potency): 23.5%
Compound 4: the middle estimate sits 6.5 percentage points above what was measured; the measured number falls inside the stated range.
By their numbers in this assay, from the lowest: compounds 1, 2 and 4 (each within the scatter of the next); then compound 3.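

In this assay, the bromo on an aromatic carbon of the shared core now has a step of its own: hydrogen in its place gives no change at the digits printed from compound 1 to compound 4 (within the scatter) and so leaves the read-out where it stood. The bromo at this position is thus not needed to hold the level of compound 1 at this one dose, and the earlier step, no change at the digits printed from compound 1 to compound 2 (within the scatter) with methyl in place of bromo, concerned a different place on the molecule. No measurement at hand gives a reason for this flat result.

From the compounds shown here alone, only bromo and hydrogen have been compared at this core position, so it remains open whether a larger or different group there, such as a methoxy group, an amine or a carboxylic acid, would move the read-out. Compound 3, at 41.1% in this assay, differs from compound 1 in more than one place, and no single change yet accounts for its number.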